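Methylating the Amine: A Step Awaiting Its Number

A few compounds are considered here, and "the series" means these few. Any claim that something is new, unique, unknown or untested is made for them only; others in the source may bear on it.

Measured so far:
compound 1, `c1cncc(CN[C@H]2C3C4CC5C6C4CC3C6C52)c1`, "not determined" (no result reported) in an assay on isolated protein for inhibition of Alpha-2C adrenergic receptor (Homo sapiens); on this read-out lower numbers stand for stronger inhibition and higher numbers for weaker inhibition;
compound 2, `Fc1cccc(CCCN[C@H]2C3C4CC5C6C4CC3C6C52)c1`, "not determined" (no result reported);
compound 3, `CN(CCCc1cccc(F)c1)[C@H]1C2C3CC4C2C(=O)C2C4C3C21`, 2790 nM.

Compound 2 therefore stands without a number in this assay, and compound 1 stands in the same position; only compound 3 carries a result. Compound 4, `CN(CCCc1cccc(F)c1)[C@H]1C2C3CC4C5C3CC2C5C41`, is the compound to be measured. It differs from compound 2 in one place: methyl in place of hydrogen on an amine nitrogen.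

Because compound 2 has no value, the size and direction of the step to compound 4 cannot be read from a measured pair. What can be said comes from compound 3, which carries the same two substituents on its amine nitrogen as compound 4 and differs from it only in the core. Compound 3 gives 2790 nM, a weak result. Compound 4 is expected to land near that figure, estimated at 2000 nM, with a range from 400 nM to 9000 nM.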

Compound 4, inhibition constant: 3730 nM
Estimate against measurement, compound 4: 1.9-fold (0.27 log units) below, within the range that was stated.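

In this assay, among the compounds shown here, compound 4 gives 3730 nM but compound 2 has no single number, so no step between compound 2 and compound 4 can be read. Going by these compounds, what methyl in place of hydrogen on the amine nitrogen does to this read-out stays open. No evidence bears on the result.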